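A few compounds are considered here, and "the series" means these few. Any claim that something is new, unique, unknown or untested is made for them only; others in the source may bear on it.

Compound 1, `CC[C@H](C)[C@H](N)CN(C(=O)[C@@H]1C[C@H]1c1ccccc1)c1ccc(-c2ccccc2)cc1`, in a functional assay for agonist activity at G protein-coupled receptor 88 (Homo sapiens), read by HTRF and cAMP accumulation (a higher number here means that more compound is needed for the effect, a lower number that less compound is needed), gives 230 nM; 800 nM (2 entries).
Compound 2, `CCc1ccc(-c2ccc(N(C[C@@H](N)[C@@H](C)CC)C(=O)[C@@H]3C[C@H]3c3ccccc3)cc2)cc1`, gives 44 nM.
Compound 3, `CC[C@H](C)[C@H](N)CN(C(=O)[C@@H]1C[C@H]1c1ccccc1)c1ccc(-c2ccc(Oc3ccccc3)cc2)cc1`, gives 94 nM.

Compound 3 stands at the higher of the two single numbers in this assay; its nearest neighbour is compound 2, with a 2.1-fold higher number from compound 2 to compound 3 (0.33 log units; beyond the scatter). Compound 1 contributes no single number, only the two entries of the several entries of compound 1 in this assay, 230 nM; 800 nM (2 entries), which spread wider than the gap between compound 2 and compound 3.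

Compound 4, `CCOC(=O)c1ccc(-c2ccc(N(C[C@@H](N)[C@@H](C)CC)C(=O)[C@@H]3C[C@H]3c3ccccc3)cc2)cc1`, has not been measured. It differs from compound 3 by ethoxycarbonyl in place of phenoxy on an aromatic carbon. Among the compounds with values here, no measured step exchanges a phenoxy for an ethoxycarbonyl, so only the one change at this position, a 2.1-fold higher number from compound 2 to compound 3 (0.33 log units; beyond the scatter), bears on it, and that step was modest. On that basis the change is expected to move the number little, with a slight lean toward a higher value, and the step from compound 3 to compound 4 is estimated as a 1.6-fold higher number from compound 3 to compound 4 (0.20 log units; within the scatter). Compound 4 is therefore expected to give about 150 nM, within a range of 40 nM to 600 nM.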

Compound 4, half-maximal effective concentration: 260 nM
Beside the measured number, compound 4's estimate is 1.7-fold (0.24 log units) below it, within the range that was stated.
By their numbers in this assay, from the lowest: compound 2; then compound 3; then compound 4.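

Within the data shown here, at this position, on an aromatic carbon para to a large group, ethoxycarbonyl gives the largest steps so far in this assay: a 2.8-fold higher number from compound 3 to compound 4 (0.44 log units; beyond the scatter) and a 5.9-fold higher number from compound 2 to compound 4 (0.77 log units; beyond the scatter). Ethoxycarbonyl has fewer heavy atoms than phenoxy yet gives the higher number, so across these two groups the number does not rise with heavy-atom count. Even so, the single number of compound 4 falls inside the span of the entries for compound 1, which has neither group at this position: the several entries of compound 1 in this assay, 230 nM; 800 nM (2 entries).

Going by these compounds, whether the higher number goes with the carbonyl or with the ethyl ester as a whole remains open, and a carboxylic acid or a primary amide at this position would separate the two. Also open, on these data alone, is whether a longer alkyl chain would stay close to ethyl.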